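Hydroxy in Place of Trifluoromethyl: Expected Tolerance on Vero Cells

The source may report more compounds than this note shows. Statements on the series, on what has been measured and on what is new or still open speak of the compounds shown alone.

Measured compounds:
compound 1 `O=c1[nH]c(Nc2cc(Cl)cc(Cl)c2)nc2cc(Cl)ccc12`: > 25000 nM
compound 2 `O=c1[nH]c(Nc2cc(F)cc(F)c2)nc2cc(C(F)(F)F)ccc12`: >= 7600 nM

In an ADME assay on Vero cells (Chlorocebus sabaeus) for cytotoxicity, read by WST assay (a higher number here means that more compound is tolerated, a lower number that less compound is tolerated), compound 1 gives > 25000 nM, which is a limit of the assay and not a number (the limit of > 25000 nM in this assay, at which 1 of the 2 values shown sits). In this assay compound 2 gives >= 7600 nM, again only a limit (the limit of >= 7600 nM in this assay, at which 1 of the 2 values shown sits). Among the compounds with values here, compound 2 therefore stands at a limit, and the one other value shown is a limit as well; no step between measured compounds is known.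

Compound 3 `O=c1[nH]c(Nc2cc(F)cc(F)c2)nc2cc(O)ccc12` differs from compound 2 by hydroxy in place of trifluoromethyl on an aromatic carbon. With both known values sitting at limits, the step that the limit leaves unreadable from compound 2 to compound 3 is expected to be none beyond the scatter, in no set direction. Compound 3 is estimated in this assay at 20000 nM, with a range from 7000 nM to 60000 nM, and most likely reported again only as a limit.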

Compound 3, half-maximal cytotoxic concentration: > 25000 nM
Compound 3 gave a limit, no number (the forecaster's own chance of this, stated with the estimate: 70%); at least 1.2-fold (0.09 log units) between middle value and limit.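

Within the data shown here, compound 2 and compound 3 both sit at limits of this assay, not at numbers, so no step between them can be read. The compounds shown leave open whether hydroxy in place of trifluoromethyl on an aromatic carbon changes tolerance at all, and in which direction.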